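Swapping a Chain-End Sulfone for a Tetrazole

A few compounds are considered here, and "the series" means these few. Any claim that something is new, unique, unknown or untested is made for them only; others in the source may bear on it.

Going by the values given here, compound 2 `CCc1cc(C(C)=O)c(O)cc1OCCCCCCS(C)(=O)=O` holds the higher of the two numbers measured so far in an assay on isolated protein for binding affinity to leukotriene B4 receptor 1 (Homo sapiens), tested at 1 uM; on this read-out higher numbers stand for more inhibition at the one concentration tested (going by the name of the read-out) and lower numbers for less inhibition: in this assay compound 2 gives 62%, while compound 1 `CCc1cc(C(C)=O)c(O)cc1OCCCC(C)(C)C#N` gives 46%. Among the compounds with values here, the one measured step, a number 16 percentage points higher from compound 1 to compound 2 (beyond the scatter), put 3-(methylsulfonyl)propyl in place of 1-cyano-1-methylethyl on a saturated chain carbon, three bonds along the chain from an oxygen on an aromatic ring, and the rise lay beyond the scatter.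

Compound 3 `CCc1cc(C(C)=O)c(O)cc1OCCCCCCc1nnn[nH]1` has not been measured. It differs from compound 2 as follows: 1H-tetrazol-5-yl in place of methylsulfonyl on a saturated chain carbon, six bonds along the chain from an oxygen on an aromatic ring. The chain keeps its length; only the group at its end changes.

Within the data shown here, no measured step exchanges a methylsulfonyl for a 1H-tetrazol-5-yl, so the only guidance is indirect: the step of a number 16 percentage points higher from compound 1 to compound 2 (beyond the scatter) shows that the group at the chain end can move the number by a modest amount in either direction. Compound 3 is therefore expected to give about 58%, with a plausible range from 30% to 85%. Against compound 2 this estimate means an expected step of a number 4 percentage points lower from compound 2 to compound 3 (within the scatter), which may well stay within the scatter.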

Compound 3, a percentage reported as inhibition, at one concentration (the size of the read-out at that concentration, not a potency): 60%
Compound 3: the middle estimate sits 2 percentage points below what was measured, within the range that was stated.
By their numbers in this assay, from the lowest: compound 1; then compounds 3 and 2 (each within the scatter of the next).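

In this assay, the exchange at the chain end gives a number 2 percentage points lower from compound 2 to compound 3 (within the scatter), so methylsulfonyl, which has no ring and no hydrogen-bond donor, and 1H-tetrazol-5-yl, a five-membered aromatic ring with a hydrogen-bond donor, cannot be told apart at this place despite those differences in what they are built from. The second step, a number 14 percentage points higher from compound 1 to compound 3 (beyond the scatter), shows that the gain over 1-cyano-1-methylethyl, three bonds along the chain from an oxygen on an aromatic ring, is not tied to the sulfone: among these three compounds, it appears with 3-(1H-tetrazol-5-yl)propyl as well as with 3-(methylsulfonyl)propyl. Nothing measured on these compounds explains why the two chain ends read alike or why both differ from the branched nitrile.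

The compounds shown leave open whether a carboxylic acid or an amine at the same chain end would give a similar number, and whether a shorter or longer chain would still carry 1H-tetrazol-5-yl equally well. Since the read-out comes from one concentration and is not a potency, they also leave open whether compound 2 and compound 3 would still read alike across a range of concentrations.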